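This account rests on a few compounds, and the source may have more. Where it says the series, first, only, none or still open, it means among the compounds named here.

Compounds measured so far:
compound 1, `COc1ccccc1NC(=S)N/N=C/c1ccc2ccccc2n1`: > 100000 nM
compound 2, `CN(C)C(=S)N/N=C/c1cc2cccnc2s1`: 21400 nM
compound 3, `NC(=S)N/N=C/c1cc2ccccc2s1`: > 100000 nM

All three were tested in a functional assay on SGC-7901 cells (Homo sapiens) for antiproliferative activity, read by sulforhodamine B assay, with a stated time of 72 h; on this read-out lower numbers stand for stronger inhibition and higher numbers for weaker inhibition. For compound 1 the result > 100000 nM is a limit of the assay, not a number. Compound 3 likewise sits at a limit, > 100000 nM. Only compound 2 gives a numeric value, 21400 nM. The picture is thus shaped by the limit of > 100000 nM in this assay, at which 2 of the 3 values shown sit, and compound 1 stands at that weak end. Compound 4, `NC(=S)N/N=C/c1ccc2ccccc2n1`, differs from compound 1 in one place: hydrogen in place of 2-methoxyphenyl on an amide-type nitrogen. Among the compounds with values here, no step between measured compounds is available for comparison, so the step from compound 1 to compound 4 in this assay is expected to stay within the scatter, as a number no higher from compound 1 to compound 4 (the limit leaves the size open). Compound 4 is therefore estimated at 100000 nM, with an expected range from 30000 nM to 300000 nM.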

Compound 4, half-maximal inhibitory concentration: 32700 nM
Compound 4: the middle estimate sits 3.1-fold (0.49 log units) above what was measured, and the stated range covers the measured number.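

In this assay, putting hydrogen in place of 2-methoxyphenyl on the amide-type nitrogen gives an at least 3.0-fold lower number from compound 1 to compound 4 (0.48 log units; beyond the scatter). Within the data shown here, this is the first pair here that differs in one place, and it shows that this nitrogen needs no aryl group for a numeric value to appear on this core. The step has only a lower bound because compound 1 sits at a limit: the limit of > 100000 nM in this assay, at which 2 of the 4 values shown sit.

Going by these compounds, how large the true step is stays open. Also open, on these data alone, is how a plain phenyl or an ethyl group on this nitrogen would read, which would separate the effect of the ring from that of its methoxy group.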